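A heptyl chain on the core of compound 1

This account rests on a few compounds, and the source may have more. Where it says the series, first, only, none or still open, it means among the compounds named here.

Compound 1 `CCOC(=O)C1(Cc2ccccc2)CN(c2ccccc2)Cc2nnn(Cc3cc(OC)c(OC)c(OC)c3)c21`: >= 100000 nM, a limit
Compound 2 `CCOC(=O)C1(Cc2ccccc2)CN(c2ccccc2)Cc2nnn(Cc3ccc(F)cc3)c21`: >= 100000 nM, a limit
Compound 3 `CCOC(=O)C1(Cc2ccccc2)CN(c2ccccc2)Cc2nnn(CCCCCO)c21`: > 100000 nM, a limit

In an ADME assay on HEL cells (Homo sapiens) for cytotoxicity, read by microscopy, with a stated time of 3 days (a higher number here means that more compound is tolerated, a lower number that less compound is tolerated), compound 1 gives >= 100000 nM, which is a limit of the assay and not a number. Compound 2 gives >= 100000 nM, again a limit. Compound 3 gives > 100000 nM, likewise a limit. Because all three sit at limits, the three steps among them cannot be sized: a step that the two limits leave unreadable from compound 1 to compound 2; a step that the two limits leave unreadable from compound 1 to compound 3; a step that the two limits leave unreadable from compound 2 to compound 3. Among the measured compounds shown here, the only evidence is the limit of > 100000 nM in this assay, at which 1 of the 3 values shown sits, and (the limit of >= 100000 nM in this assay, at which 2 of the 3 values shown sit).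

Compound 4 `CCCCCCCCn1nnc2c1C(Cc1ccccc1)(C(=O)OCC)CN(c1ccccc1)C2` differs from compound 1 in one place: heptyl in place of 3,4,5-trimethoxyphenyl on a saturated chain carbon bound to an aromatic nitrogen. The change at that same position in compound 2 and compound 3 left the readout at a limit both times, so no step beyond the scatter is expected here either, and the step from compound 1 to compound 4 is estimated as a number no higher from compound 1 to compound 4 (the limit leaves the size open). Compound 4 is therefore expected to give about 100000 nM in this assay, within a range from 50000 nM to 200000 nM, most likely again as a limit.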

Compound 4, minimum cytotoxic concentration: >= 20000 nM
Compound 4 was reported as a limit; the forecaster's own chance of this, stated with the estimate: 85%; the middle value lies beyond the limit too.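

In this assay compound 4 gives >= 20000 nM, a limit of the assay and not a number. Among the compounds shown here, no step to compound 4 from compound 1, compound 2 or compound 3 can be read, since all four values are limits. The compounds shown leave open whether the heptyl chain changes tolerance at all.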